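Shifting the anilino substituent on a fused quinone core

This account rests on a few compounds, and the source may have more. Where it says the series, first, only, none or still open, it means among the compounds named here.

The measured compounds are:
compound 1 `O=C1C(Nc2ccccc2F)=CC(=O)c2c1nc1n2[C@H]2OC[C@@H](O)[C@H]2OC1` with 2000 nM
compound 2 `O=C1C=C(Nc2ccccc2F)C(=O)c2c1nc1n2[C@H]2OC[C@@H](O)[C@H]2OC1` with 2080 nM
compound 3 `O=C1C=C(Nc2ccc(Br)cc2)C(=O)c2c1nc1n2[C@H]2OC[C@@H](O)[C@H]2OC1` with 1010 nM

In a functional assay on MGC-803 cells (Homo sapiens) for inhibition, read by sulforhodamine B assay (a lower number here means a stronger inhibitor, a higher number a weaker inhibitor), compound 1 gives 2000 nM. That number sits within the scatter of the value of compound 2 and also within the scatter of the value of compound 3, so the three measured compounds cannot be placed in a firm order on these numbers alone.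

The unmeasured compound 4 `CCCc1ccc(NC2=CC(=O)c3c(nc4n3[C@H]3OC[C@@H](O)[C@H]3OC4)C2=O)cc1` keeps the shared core of compound 1 and differs from it only at the anilino group: 4-propylphenyl in place of 2-fluorophenyl on an amine nitrogen.

Going by the values given here, one measured step bears on this change. From compound 2 to compound 3, with 4-bromophenyl in place of 2-fluorophenyl on an amine nitrogen, this assay moved by a 2.1-fold lower number from compound 2 to compound 3 (0.31 log units; beyond the scatter). Among the compounds with values here, that step is on a regioisomeric core, and 4-propylphenyl is not 4-bromophenyl, but it is the only guide available for exchanging 2-fluorophenyl for a 4-substituted phenyl.

Within the data shown here, compound 4 is therefore expected to give a modestly lower number than compound 1, a step of roughly a 1.8-fold lower number from compound 1 to compound 4 (0.26 log units; within the scatter), with the range kept wide because no propyl analogue has been measured. The estimate for compound 4 in this assay is 1100 nM, expected to fall between 450 nM and 2700 nM.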

Compound 4, half-maximal inhibitory concentration: 1920 nM
The estimate for compound 4 lay 1.7-fold (0.24 log units) below the measured number, within the range that was stated.
By their numbers in this assay, from the lowest: compounds 3, 4, 1 and 2 (each within the scatter of the next, the first and the last beyond it).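

On the core of compound 1, the exchange of 2-fluorophenyl for 4-propylphenyl on an amine nitrogen gave a 1.0-fold lower number from compound 1 to compound 4 (0.02 log units; within the scatter) in this assay, so the two groups cannot be told apart at this position on these numbers. A 4-substituted phenyl therefore does not by itself bring a step beyond the scatter here: the one such step shown, a 2.1-fold lower number from compound 2 to compound 3 (0.31 log units; beyond the scatter), involves 4-bromophenyl rather than 4-propylphenyl and sits on the regioisomeric core, so it did not carry over to this pair. Nothing shown explains why the two steps differ in this way.

On these data alone, it remains open whether the larger step belongs to the bromine-bearing group or to the regioisomeric core, a question that 4-bromophenyl on the core of compound 1 or 4-propylphenyl on the core of compound 3 would settle. Also open, as far as these compounds go, is whether a phenyl group carrying an amine, a carboxylic acid or a chain longer than propyl at the same place would separate itself from 2-fluorophenyl in this cell assay.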